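Swapping a methylsulfamoyl for a carboxy: solubility outlook

The compounds below may be only part of what the source reports. "The series", "measured", "known", "first", "only" and "open" are said of these compounds alone.

Three compounds have been measured so far:
compound 1, `CNS(=O)(=O)c1ccc(-c2cnc(N)c(-c3ccc(OC)nc3)c2)cc1`, with 12.5 ug/mL;
compound 2, `COc1ccc(-c2cnc(N)c(-c3ccc(OC)nc3)c2)cn1`, with 25 ug/mL;
compound 3, `COc1ccc(-c2cc(-c3ccc4cnn(C)c4c3)cnc2N)cn1`, with 6.3 ug/mL.

All three share the same core and were run in a physicochemical assay for solubility, read by nephelometry, in phosphate buffer, measured as kinetic solubility, at pH 6.5; a lower number here means a less soluble compound, a higher number a more soluble compound. Compound 1 sits in the middle of the three numbers, but its gaps to compound 2 and to compound 3 both lie within the scatter of repeated measurements, so the three values cannot be told apart with confidence.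

Compound 4, `COc1ccc(-c2cc(-c3ccc(C(=O)O)cc3)cnc2N)cn1`, has not been measured. It differs from compound 1 in one place: carboxy in place of methylsulfamoyl on an aromatic carbon. Within the data shown here, no pair of measured compounds shows exactly this exchange, so there is no measured step to lean on. Even so, a rise beyond the scatter is expected, since compound 1 with its 12.5 ug/mL sits low and the exchange is a sizeable change in the group carried at that position. The estimate for compound 4 is 40 ug/mL, with a range from 12 ug/mL to 130 ug/mL, which is expected to mean a step of a 3.2-fold higher number from compound 1 to compound 4 (0.51 log units; beyond the scatter).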

Compound 4, solubility: 6.3 ug/mL
Estimate against measurement, compound 4: 6.3-fold (0.80 log units) above, outside the stated range (below it).
By their numbers in this assay, from the lowest: compounds 3, 4, 1 and 2 (each within the scatter of the next, the first and the last beyond it).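

The exchange of carboxy for methylsulfamoyl, on an aromatic carbon para to a large group, gives a 2.0-fold lower number from compound 1 to compound 4 (0.30 log units; within the scatter) in this assay and so compound 1 and compound 4 cannot be told apart. Among these compounds, this pair gives the first direct comparison at this position: a group of three heavy atoms stands in place of one of five, and the two readings remain within the usual scatter of repeated measurements. Nothing at hand explains why these two groups read alike.

The compounds shown leave open whether a different group at this position, such as an aminomethyl group or a methyl ester, would give a step beyond the scatter. Among the compounds shown here, they also leave open whether this same exchange would read alike on another core, since only this one pair carries it.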